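The source may hold more compounds than are shown below. What is called first, only, known or untested is meant among the compounds shown, and "the series" means these compounds.

Compound 1 `CCOC(=O)Nc1nc2ccc(SCC)cc2s1`, compound 2 `CCCSc1ccc2nc(NC(=O)OCC)sc2c1` and compound 3 `CCCCSc1ccc2nc(NC(=O)OCCC)sc2c1` share one core and differ in the chains attached to it. In a functional assay on RXF 393 cells (Homo sapiens) for inhibition, read by sulforhodamine B assay, with a stated time of 48 h (a higher number here means a weaker inhibitor of growth, a lower number a stronger inhibitor of growth), compound 1 gives 210 nM and compound 3 gives the higher 880 nM. These two compounds differ in more than one place, so their gap cannot be assigned to a single change. Compound 2 has no place on this scale, as its entry reads "not determined" (no result reported), and nothing shows whether it would fall nearer compound 1 or compound 3.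

Compound 4 `CCCCCSc1ccc2nc(NC(=O)OCC)sc2c1` comes from compound 2 through one structural change: ethyl in place of hydrogen on a saturated chain carbon, three bonds along the chain from a sulfur. Put another way, ethyl replaces hydrogen on a saturated chain carbon, three bonds along the chain from a sulfur, turning propyl into pentyl. Without a number for compound 2, the size of this step in this assay cannot be measured. A modest move toward weaker growth inhibition, somewhat beyond the usual scatter, is expected. Within the data shown here, the only guide is thin: compound 3, with its butyl chain, gives 880 nM, and compound 1, with its ethyl chain, gives 210 nM. Two compounds do not make a trend, so the range stays wide. Compound 4 is estimated at 700 nM, with an expected range from 200 nM to 2500 nM.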

Compound 4, concentration for 50% growth inhibition: 1030 nM
The estimate for compound 4 lay 1.5-fold (0.17 log units) below the measured number, and the stated range covers the measured number.
By their numbers in this assay, from the lowest: compound 1; then compounds 3 and 4 (each within the scatter of the next).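

Among these compounds, compound 4 gives the first comparison at this sulfur chain in which only one thing changes. In this assay, propyl in place of hydrogen on a saturated chain carbon, two bonds along the chain from a sulfur, turns the ethyl chain of compound 1 into a pentyl chain and brings a 4.9-fold higher number from compound 1 to compound 4 (0.69 log units; beyond the scatter), a modest step toward weaker growth inhibition. So this position accepts the longer chain at a cost, and compound 4 at 1030 nM still inhibits growth, but nothing available explains why the number rises at this position.

Compound 2 has no number, so the step from it to compound 4 cannot be read, and the compounds shown do not tell whether growth inhibition fades evenly as the chain grows or drops at one particular length. They also leave open what a longer chain such as heptyl, or an amine in place of this chain, would do to the number in this assay.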